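Moving the methoxy group: working notes on cytotoxicity limits

This account rests on a few compounds, and the source may have more. Where it says the series, first, only, none or still open, it means among the compounds named here.

- Compound 1 `COc1cc2nc([S+]([O-])CC(=O)Nc3ccccc3C(F)(F)F)nc(Nc3c(Cl)cc(/C=C/C#N)cc3Cl)c2cc1OC` in an ADME assay on MT4 cells (Homo sapiens) for cytotoxicity, read by MTT assay, with a stated time of 5 days; a higher number here means that more compound is tolerated, a lower number that less compound is tolerated: > 192000 nM (a limit)
- Compound 2 `COc1ccccc1NC(=O)C[S+]([O-])c1nc(Nc2c(Cl)cc(/C=C/C#N)cc2Cl)c2cc(OC)c(OC)cc2n1` in this assay: > 204000 nM (a limit)

Compound 2 has no numerical value, only a limit: the limit of > 204000 nM in this assay, at which 1 of the 2 values shown sits. Compound 3 `COc1cccc(NC(=O)C[S+]([O-])c2nc(Nc3c(Cl)cc(/C=C/C#N)cc3Cl)c3cc(OC)c(OC)cc3n2)c1` carries 3-methoxyphenyl in place of 2-methoxyphenyl on an amide-type nitrogen. Within the data shown here, the only measured step, a step that the two limits leave unreadable from compound 1 to compound 2, involves methoxy in place of trifluoromethyl on an aromatic carbon and offers no size to carry over. No change beyond the scatter is expected in this assay, in either direction, and the expected step is an at least 1.0-fold lower number from compound 2 to compound 3 (0.00 log units; that floor lies within the scatter). Compound 3 is estimated at 200000 nM, with an expected range of 80000 nM to 300000 nM.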

Compound 3, half-maximal cytotoxic concentration: >= 167000 nM
Compound 3: only a limit was reported; the forecaster's own chance of this, stated with the estimate: 75%; the middle value does not contradict the limit.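

In this assay, among these compounds, compound 1, compound 2 and compound 3 each give only a limit, so no step among them can be read. The compounds shown leave open whether 3-methoxyphenyl in place of 2-methoxyphenyl changes tolerance at all.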